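The source may report more compounds than this note shows. Statements on the series, on what has been measured and on what is new or still open speak of the compounds shown alone.

Three compounds of a shared core, each carrying a basic chain on that core, have been measured for cytotoxicity in an ADME assay on Huh-7 cells (Homo sapiens) for cytotoxicity (on this read-out higher numbers stand for lower toxicity in this test and lower numbers for higher toxicity in this test), and all three sit at the same boundary. Compound 1 `Cc1ccccc1-c1nn(-c2ccc(F)cc2F)cc1CNCCN1CCCCC1` gives > 20000 nM in this assay, which is a limit of the assay and not a number. Compound 3 `Cc1ccccc1-c1nn(C(C)C)cc1CNCCN1CCN(C)CC1` likewise gives > 20000 nM in this assay, again a limit. Compound 2 `CN1CCN(CCNCc2cn(-c3ccc(F)cc3F)nc2-c2ccccc2)CC1` stands at > 20000 nM in this assay, a limit as well, so no number places it relative to the others (the limit of > 20000 nM in this assay, at which 3 of the 3 values shown sit). Compound 4 `Cc1ccc(-c2nn(-c3ccc(F)cc3F)cc2CNCCN2CCN(C)CC2)cc1` differs from compound 2 by methyl in place of hydrogen on an aromatic carbon, a methyl in place of hydrogen on an aromatic carbon. With every value at this limit, no step beyond the scatter is expected from compound 2 to compound 4, giving a step that the limit leaves unreadable from compound 2 to compound 4. Compound 4 is therefore expected to show 30000 nM, between 15000 nM and 100000 nM.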

Compound 4, half-maximal cytotoxic concentration: > 20000 nM
Compound 4: no number, only a limit; the forecaster's own chance of this, stated with the estimate: 85%; the middle value is on the limit's open side.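

Compound 2 and compound 4 both sit at a limit of the assay rather than at a number, so no step can be read for the methyl in place of hydrogen. The compounds shown leave open what actual value any of them would reach in this assay.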